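Hydroxy in place of fluoro on compound 3

The compounds below may be only part of what the source reports. "The series", "measured", "known", "first", "only" and "open" are said of these compounds alone.

In a functional assay on HeLa cells (Homo sapiens) for antiproliferative activity, read by MTT assay, with a stated time of 48 h (a higher number here means a weaker inhibitor, a lower number a stronger inhibitor), compound 3 `COc1ccc(N(C)c2cc(C)nc(C)n2)cc1F` at 471 nM and compound 1 `COc1ccc(N(C)c2ccnc(Cl)n2)cc1Cl` at 517 nM lie within the scatter of each other. Compound 2 `COc1ccc(N(C)c2ccnc(Cl)n2)cc1OCCCC[Se]C#N` gives > 10000 nM as a limit of the assay. The change hydroxy in place of fluoro on an aromatic carbon puts hydroxy in place of fluoro on an aromatic carbon, ortho to a methoxy group, and gives compound 4 `COc1ccc(N(C)c2cc(C)nc(C)n2)cc1O` as the next member. For the measured compounds named here, the only measured step of an at least 19-fold higher number from compound 1 to compound 2 (1.28 log units; beyond the scatter) is large but replaces chlorine with a far bigger group, so it bears only weakly on an exchange of one heavy atom for another. No step beyond the scatter is therefore expected in this assay in either direction. The expected step is a 1.0-fold lower number from compound 3 to compound 4 (0.02 log units; within the scatter) with wide uncertainty. Compound 4 is estimated at 450 nM with 120 nM to 1800 nM as the expected range.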

Compound 4, half-maximal inhibitory concentration: 93 nM
Beside the measured number, compound 4's estimate is 4.8-fold (0.68 log units) above it, and the stated range ends above it.
By their numbers in this assay, from the lowest: compound 4; then compounds 3 and 1 (each within the scatter of the next). At a limit, above all of these: compound 2.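

In this assay, the aromatic carbon ortho to a methoxy group proves sensitive to a single heavy-atom exchange, with a 5.1-fold lower number from compound 3 to compound 4 (0.70 log units; beyond the scatter) as hydroxy replaces fluoro. For the compounds shown here, until now, the only reading at this place was the chain of compound 2, which gives a limit of > 10000 nM. Nothing shown accounts for the gain with hydroxy. Open, from the compounds shown here alone, is whether an amine or a carboxylic acid on this carbon would match hydroxy. Also open, going by these compounds, is whether hydroxy gives the same gain on the core of compound 1.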